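The source may hold more compounds than are shown below. What is called first, only, known or untested is meant among the compounds shown, and "the series" means these compounds.

Compound 1 `Cc1cc(C(=O)O)ccc1CN1CCC[C@H](O[C@H](CO)c2ccccc2)[C@@H]1c1ccccc1` was examined in an assay on isolated protein for activation of cGMP-dependent protein kinase 1 (Homo sapiens), read by ADP-Glo, with stated times of 30 min and 2 h; a lower number here means that less compound is needed, a higher number that more compound is needed for the effect. In this assay compound 1 reaches only a limit, > 200000 nM, which marks the edge of the assay and is not a number. For compound 2 `Cc1cc(C(=O)O)ccc1C(C)N1CCC[C@H](O[C@H](CO)c2cc(Cl)cc(Cl)c2)[C@@H]1c1ccccc1` the entry in this assay reads "nd" (no result reported), so no result is available. Compound 3 `Cc1cc(C(=O)O)ccc1CN1CCC[C@H](O[C@H](CO)c2cc(Cl)nc(Cl)c2)[C@@H]1c1ccccc1` is the next candidate and carries 2,6-dichloropyridin-4-yl in place of phenyl on a saturated chain carbon bound to an oxygen on a saturated carbon and a saturated chain carbon. For the measured compounds named here, no measured step between compounds is at hand, and compound 1 rests at the limit of > 200000 nM in this assay, at which 1 of the 2 values shown sits. The change is therefore expected to bring little movement beyond the scatter, an at least 1.6-fold lower number from compound 1 to compound 3 (0.22 log units; that floor lies within the scatter). Compound 3 is estimated at 120000 nM, with a range from 20000 nM to 600000 nM.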

Compound 3, half-maximal effective concentration: > 200000 nM
Compound 3 ended at the assay's limit; the forecaster's own chance of this, stated with the estimate: 60%; middle value at least 1.6-fold (0.22 log units) away from the limit.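

For the compounds shown here, compound 1 and compound 3 both end at a limit and not at a number, so no step between them can be read. The compounds shown leave open which change to the shared core would give a number in this assay.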